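Substituent change on the aromatic carbon of compound 2

A few compounds are considered here, and "the series" means these few. Any claim that something is new, unique, unknown or untested is made for them only; others in the source may bear on it.

Compound 2 `COC(=O)[C@@]1(C)CCC=C2[C@@H]1CC[C@@H](C)[C@]2(C)Cc1c[nH]c2ccc(OC)cc12` carries a methoxy group on an aromatic carbon, and in a functional assay on SW1573 cells (Homo sapiens) for inhibition, read by sulforhodamine B assay, with a stated time of 48 h (a lower number here means a stronger inhibitor of growth, a higher number a weaker inhibitor of growth), compound 2 gives 1300 nM, the lowest of the two numbers recorded so far. Among the measured compounds shown here, its only measured neighbour is compound 1 `COC(=O)[C@@]1(C)CCC=C2[C@@H]1CC[C@@H](C)[C@]2(C)Cc1c[nH]c2ccc(Br)cc12`, which carries bromo at the same place; in this assay compound 1 gives 12000 nM. For the measured compounds named here, the one measured step is a 9.2-fold lower number from compound 1 to compound 2 (0.97 log units; beyond the scatter). Compound 3 `COC(=O)[C@@]1(C)CCC=C2[C@@H]1CC[C@@H](C)[C@]2(C)Cc1c[nH]c2ccc(C(F)(F)F)cc12` differs from compound 2 in one place: trifluoromethyl in place of methoxy on an aromatic carbon. Going by the values given here, the only measured step that bears on this change is the bromo-to-methoxy step just described, a modest one at the same aromatic carbon; no step between methoxy and trifluoromethyl has been measured, and nothing here shows how trifluoromethyl compares with bromo. Compound 3 is therefore expected to fall between the two measured numbers rather than beyond them. The expected step is a 3.8-fold higher number from compound 2 to compound 3 (0.59 log units; beyond the scatter). The estimate for compound 3 in this assay is 5000 nM, with a range from 1500 nM to 20000 nM.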

Compound 3, concentration for 50% growth inhibition: 14000 nM
For compound 3 the middle estimate is 2.8-fold (0.45 log units) below the measured one; the range from low to high includes it.
By their numbers in this assay, from the lowest: compound 2; then compounds 1 and 3 (each within the scatter of the next).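

At this aromatic carbon, this assay now gives two separate steps away from methoxy. Trifluoromethyl in place of methoxy gives an 11-fold higher number from compound 2 to compound 3 (1.03 log units; beyond the scatter), a step comparable in size to the earlier one, a 9.2-fold lower number from compound 1 to compound 2 (0.97 log units; beyond the scatter), while trifluoromethyl in place of bromo gives a 1.2-fold higher number from compound 1 to compound 3 (0.07 log units; within the scatter), so these two groups cannot be told apart here and compound 2 stands alone as the strongest inhibitor of growth among the three. Methoxy is therefore the only one of the three groups at this carbon that separates from the others, and nothing available accounts for this difference between the groups.

Three groups at one carbon cannot show whether the lower number depends on the oxygen attached to the ring or belongs to methoxy alone, and hydroxy, ethoxy, a longer alkoxy chain or an amine at this place would test that. Also open, going by these compounds, is whether compound 2 would keep its standing against the core with plain hydrogen at this carbon, and whether the same order of groups holds on the other carbons of this ring.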